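This account rests on a few compounds, and the source may have more. Where it says the series, first, only, none or still open, it means among the compounds named here.

Compound 1 `CS(=O)(=O)c1ccc(-c2cnc3[nH]cc(-c4nnc(-c5ccccc5)o4)c(=O)c3c2)cc1` belongs to a small set of three compounds sharing one core. In a functional assay on HeLa cells (Homo sapiens) for inhibition, read by MTT assay, with a stated time of 24 h, tested at 10 uM (a higher number here means more inhibition of growth at the concentration tested, a lower number less inhibition of growth), compound 1 gives 17.5%, which puts it second of the three. Compound 2 `N#Cc1ccc(-c2cnc3[nH]cc(-c4nnc(-c5ccc(Cl)cc5)o4)c(=O)c3c2)cc1` gives 13.7%, a number within the scatter of compound 1, so the two cannot be ranked; compound 3 `O=c1c(-c2nnc(-c3ccc(Cl)cc3)o2)c[nH]c2ncc(-c3ccccc3)cc12` gives 31.3%, which lies beyond the scatter above compound 1. Among the measured compounds shown here, the one step among the measured compounds, a number 17.6 percentage points higher from compound 2 to compound 3 (beyond the scatter), involves a cyano group at a different place, so it does not speak to the change in hand.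

Compound 4 `Cc1cccc(-c2nnc(-c3c[nH]c4ncc(-c5ccc(S(C)(=O)=O)cc5)cc4c3=O)o2)c1` differs from compound 1 by methyl in place of hydrogen on an aromatic carbon. For the measured compounds named here, with no comparable step among the measured compounds, no change beyond the scatter is expected in this assay; the expected step is a number 2.5 percentage points higher from compound 1 to compound 4 (within the scatter). Compound 4 is therefore estimated at 20%, within a range from 7% to 36%.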

Compound 4, percent growth inhibition at one concentration: 2.57%
Estimate against measurement, compound 4: 17.4 percentage points above; the measured number lies below the stated range.
By their numbers in this assay, from the lowest: compound 4; then compounds 2 and 1 (each within the scatter of the next); then compound 3.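

In this assay, among the compounds shown here, the change from phenyl to 3-methylphenyl gives a number 14.9 percentage points lower from compound 1 to compound 4 (beyond the scatter) and provides the first measured step at this position. It shows that a single added methyl, only one heavy atom, on this ring can lower growth inhibition at the concentration tested. Nothing measured here accounts for the drop. Still open, as far as these compounds go, is whether the loss is particular to methyl or would also follow from an ethyl group, an amine or a carboxylic acid at the same place. Also open, from the compounds shown here alone, is whether methyl would produce a similar step in compound 3.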